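Removing one fluoro group from compound 2

This account rests on a few compounds, and the source may have more. Where it says the series, first, only, none or still open, it means among the compounds named here.

- compound 1 `O=C1C=CC2(C=C1)OCC(=O)N2c1nc(-c2ccc3ncccc3c2)nn1-c1ccccc1` gives 50 nM
- compound 2 `O=C1C=CC2(C=C1)OCC(=O)N2c1nc(-c2ccc(F)c3ccccc23)nn1-c1ccccc1` gives 80 nM

For the measured compounds named here, in a functional assay on MDA-MB-231 cells (Homo sapiens) for antiproliferative activity, with a stated time of 5 days (on this read-out higher numbers stand for weaker inhibition and lower numbers for stronger inhibition), compound 2 gives 80 nM and stands within the scatter of compound 1, the only other measured compound. Going by the values given here, the one measured step is a 1.6-fold higher number from compound 1 to compound 2 (0.20 log units; within the scatter) and it exchanges quinolin-6-yl for 4-fluoronaphthalen-1-yl, so it does not test fluoro alone. Compound 3 `O=C1C=CC2(C=C1)OCC(=O)N2c1nc(-c2cccc3ccccc23)nn1-c1ccccc1` differs from compound 2 by hydrogen in place of fluoro on an aromatic carbon with hydrogen in place of fluoro on an aromatic carbon. No shift beyond the scatter is therefore expected in this assay for this change. The expected result is a 1.1-fold lower number from compound 2 to compound 3 (0.03 log units; within the scatter) in size. For compound 3 the estimate is 75 nM with an expected range from 30 nM to 200 nM.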

Compound 3, half-maximal inhibitory concentration: 50 nM
Compound 3: the middle estimate sits 1.5-fold (0.18 log units) above what was measured, within the range that was stated.
By their numbers in this assay, from the lowest: compounds 1, 3 and 2 (each within the scatter of the next).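

In this assay the fluoro group of the 4-fluoronaphthalen-1-yl group is replaced by hydrogen alone, which gives a 1.6-fold lower number from compound 2 to compound 3 (0.20 log units; within the scatter) and so tests this position directly, showing that fluoro is not needed here to stay within the scatter. Naphthalen-1-yl in place of quinolin-6-yl gives no change at the digits printed from compound 1 to compound 3 (within the scatter) and so also stays within the scatter. No measurement shown here bears on the reason for these results.

From the compounds shown here alone, whether an amine, a methoxy group or a carboxylic acid at this position would also stay within the scatter remains open.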